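The source may report more compounds than this note shows. Statements on the series, on what has been measured and on what is new or still open speak of the compounds shown alone.

- Compound 1 `O=C(Nc1cc(F)c(F)c(F)c1)N1CCCn2ncc(N3CC(c4ccccc4)CC3=O)c2C1`: > 2000 nM, a limit
- Compound 2 `CC1CCn2ncc(N3CC(c4ccccc4)CC3=O)c2CN1C(=O)Nc1cc(F)c(F)c(F)c1`: > 2000 nM, a limit
- Compound 3 `CC1(C)CC(=O)N(c2cnn3c2CN(C(=O)Nc2cc(F)c(F)c(F)c2)C(C2CC2)C3)C1`: 115000 nM

Within the data shown here, in a toxicity assay on HepG2 2.2.15 cells (Homo sapiens) for cytotoxicity, read by CellTiter-Glo (on this read-out lower numbers stand for higher toxicity in this test and higher numbers for lower toxicity in this test), compound 3 gives 115000 nM, the only true number among the three results. The remaining results are limits and not numbers, as the limit of > 2000 nM in this assay, at which 2 of the 3 values shown sit, shows.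

Compound 4 `O=C1CC(c2ncco2)CN1c1cnn2c1CN(C(=O)Nc1cc(F)c(F)c(F)c1)C(C1CC1)C2` keeps the core of compound 3 and differs in one group, with 4-(1,3-oxazol-2-yl)-2-oxopyrrolidin-1-yl in place of 4,4-dimethyl-2-oxopyrrolidin-1-yl on an aromatic carbon.

Among the measured compounds shown here, the one measured step is a step that the two limits leave unreadable from compound 1 to compound 2. For the measured compounds named here, it concerns a different change, methyl in place of hydrogen on a saturated ring carbon, so no measured step gives a size for this exchange. With compound 3 as the only anchor, a moderate move to lower numbers in this assay is expected because compound 3 at 115000 nM already lies high on the scale of the results shown. That direction remains a weak expectation, and the range around it is kept wide. The expected step is a 2.3-fold lower number from compound 3 to compound 4 (0.36 log units; beyond the scatter). Compound 4 is estimated at 50000 nM, with an expected range from 8000 nM to 200000 nM.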

Compound 4, half-maximal cytotoxic concentration: > 200000 nM
Compound 4 ended at the assay's limit (the forecaster's own chance of this, stated with the estimate: 45%); middle value at least 4.0-fold (0.60 log units) from the limit.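

At this place, on an aromatic carbon of a five-membered aromatic ring with 2 nitrogen, 4-(1,3-oxazol-2-yl)-2-oxopyrrolidin-1-yl in place of 4,4-dimethyl-2-oxopyrrolidin-1-yl gives, in this assay, an at least 1.7-fold higher number from compound 3 to compound 4 (0.24 log units; that floor lies within the scatter). Among these compounds, this is the first step with a readable bound, as the only earlier step cannot be read and concerns a saturated ring carbon; the larger group with its added aromatic ring shows no move to lower numbers, which would stand for higher toxicity in this test, although the bound alone does not establish a change beyond the scatter. The result for compound 4 is a limit of the assay and not a number: the limit of > 200000 nM in this assay, at which 1 of the 4 values shown sits.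

As far as these compounds go, how far the true value of compound 4 lies from compound 3 therefore stays open, and so does whether the exchange has any real effect at all. From the compounds shown here alone, it is also open whether a carboxylic acid or a primary amine in place of the 1,3-oxazol-2-yl group on the 2-oxopyrrolidin-1-yl ring would leave the read-out just as high.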